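Removing the methoxy group from compound 3

The source may hold more compounds than are shown below. What is called first, only, known or untested is meant among the compounds shown, and "the series" means these compounds.

Compound 3 `CCCc1nc(-c2ccccc2)c(CNCCCN2CCN(c3ccc(OC)cc3)CC2)o1` sits lowest of the three numbers measured in an assay on HEK293 cells for inhibition of Voltage-dependent T-type calcium channel subunit alpha-1G (Homo sapiens), read by fluorescence, tested at 10 uM; on this read-out higher numbers stand for more inhibition at the one concentration tested (going by the name of the read-out) and lower numbers for less inhibition: compound 3 gives 42.1%. Compound 1 `CCCc1nc(-c2ccccc2)c(CNCCN2CCN(c3ccccc3F)CC2)o1` is nearest, with 46.5% in this assay, a gap within the scatter; compound 2 `CCCc1nc(-c2ccccc2)c(CNCCN2CCN(c3ccccc3Cl)CC2)o1` is furthest, with 60.1%. Among the compounds with values here, the one measured step, a number 13.6 percentage points higher from compound 1 to compound 2 (beyond the scatter), concerns a different position and a shorter linker, so it does not bear on the present change. Compound 4 `CCCc1nc(-c2ccccc2)c(CNCCCN2CCN(c3ccccc3)CC2)o1` differs from compound 3 by hydrogen in place of methoxy on an aromatic carbon, on an aromatic carbon para to a large group. Within the data shown here, no measured pair tests this change; the estimate is therefore that compound 4 stays close to compound 3, a step of a number 1.9 percentage points higher from compound 3 to compound 4 (within the scatter), not expected to exceed the scatter. Compound 4 is estimated at 44%, within 30% to 58%.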

Compound 4, a percentage reported as inhibition, at one concentration (the size of the read-out at that concentration, not a potency): 43.7%
Compound 4: the middle estimate sits 0.3 percentage points above what was measured, and the stated range covers the measured number.
By their numbers in this assay, from the lowest: compounds 3, 4 and 1 (each within the scatter of the next); then compound 2.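

Going from 4-methoxyphenyl to phenyl gives in this assay a number 1.6 percentage points higher from compound 3 to compound 4 (within the scatter), the first measured step at this place on the ring. Methoxy, on an aromatic carbon para to a large group, can therefore be replaced by hydrogen with no change beyond the scatter at the one concentration tested. Nothing at hand offers an explanation for this result.

Still open, from the compounds shown here alone, is whether an amine or a carboxylic acid at this place would move the number beyond the scatter. Also open, going by these compounds, is whether a longer chain in the linker would leave this step as small.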